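The compounds below may be only part of what the source reports. "The series", "measured", "known", "first", "only" and "open" are said of these compounds alone.

Measured compounds:
Compound 1 `C[C@H]1C[C@H]1C(=O)N1CC2CNCC2C1`: in an assay on CHO cells for agonist activity at Neuronal acetylcholine receptor; alpha3/beta4 (Homo sapiens), read by FLIPR and calcium flux (on this read-out lower numbers stand for an effect already at smaller amounts and higher numbers for an effect only at larger amounts of compound), compound 1 gives 10000 nM.
Compound 2 `O=C(c1ccco1)[C@H]1C[C@@H]2CNC[C@@H](C2)C1`: in this assay compound 2 gives "not determined" (no result reported).

Compound 2 therefore stands nowhere on the numbers: its activity in this assay is simply unknown, and compound 1 is the only point of reference, sitting at a weak level with its value of 10000 nM. Compound 3 `CCCNC(=O)[C@H]1C[C@@H]2CNC[C@@H](C2)C1` is the next compound to be measured in this assay. It differs from compound 2 in one place: propylamino in place of furan-2-yl on a carbonyl carbon. Both compounds share the same saturated bicyclic core carrying a secondary amine, and compound 3 carries an amide where compound 2 carries a ketone. Within the data shown here, no measured pair shows what such a change does, so no step size can be read off. Guided by compound 1 at 10000 nM, a weak effect is expected for compound 3, estimated at 10000 nM with a range from 2000 nM to 30000 nM.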

Compound 3, half-maximal effective concentration: 15000 nM
Estimate against measurement, compound 3: 1.5-fold (0.18 log units) below; measured number inside the range.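

Among these compounds, compound 2 has no numerical result in this assay, so no step from compound 2 to compound 3 can be read. No available evidence bears on the value of compound 3. The compounds shown leave open how replacing furan-2-yl with propylamino changes the effect in this assay.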